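Clearance across a phenyl replacement on the shared core

A few compounds are considered here, and "the series" means these few. Any claim that something is new, unique, unknown or untested is made for them only; others in the source may bear on it.

In an ADME assay on microsomes from liver (Homo sapiens) for metabolic stability (on this read-out lower numbers stand for slow clearance and higher numbers for fast clearance), compound 1 `Cn1ncc(-c2nn(C)c3ncnc(N4CCC4)c23)c1-c1ccc(C(F)(F)F)cn1` gives 33 mL/min/kg and compound 2 `Cn1ncc(-c2nn(C)c3ncnc(N4CCC4)c23)c1-c1ccccc1` gives 34 mL/min/kg. These two numbers lie within the scatter of each other, so compound 2 stands level with compound 1, the only other measured point in the series.

The next structure, compound 3 `Cn1ncc(-c2nn(C)c3ncnc(N4CCC4)c23)c1-c1ncc(C2CC2)cn1`, differs from compound 2 as follows: 5-cyclopropylpyrimidin-2-yl in place of phenyl on an aromatic carbon. Here, 5-cyclopropylpyrimidin-2-yl takes the place of phenyl on an aromatic carbon, next to the ring atom that bears a methyl group.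

Among the compounds with values here, one measured step bears on this change: a 1.0-fold higher number from compound 1 to compound 2 (0.01 log units; within the scatter). It involves the same place and stays within the scatter. Within the data shown here, no measured compound carries a cyclopropyl group or a pyrimidine ring, so this single step is a thin guide, and no direction can be called. No step beyond the scatter is expected in this assay. The expected change is a 1.1-fold lower number from compound 2 to compound 3 (0.05 log units; within the scatter). For compound 3, the estimated clearance is 30 mL/min/kg, with an expected range of 15 mL/min/kg to 58 mL/min/kg.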

Compound 3, clearance: 28 mL/min/kg
For compound 3 the middle estimate is 1.1-fold (0.03 log units) above the measured one; the range from low to high includes it.
By their numbers in this assay, from the lowest: compounds 3, 1 and 2 (each within the scatter of the next).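

In this assay, the place on the aromatic carbon next to the ring atom that bears a methyl group now accepts 5-cyclopropylpyrimidin-2-yl, with one three-membered non-aromatic ring and 2 hydrogen-bond acceptors where phenyl has neither, and the step is a 1.2-fold lower number from compound 2 to compound 3 (0.08 log units; within the scatter). Set against 5-(trifluoromethyl)pyridin-2-yl at the same place, the step is a 1.2-fold lower number from compound 1 to compound 3 (0.07 log units; within the scatter), so the three groups shown here, which differ in ring make-up, heavy-atom count and substituent, all lie within the scatter of one another on this read-out. No measurement on hand accounts for this flat result.

Still open, going by these compounds, is whether any group at this place can move clearance beyond the scatter, for instance a pendant amine, a carboxylic acid or a longer chain in place of the cyclopropyl group on the pyrimidine ring. All three compounds share every other place on the core, so the compounds shown say nothing about how clearance responds to a change anywhere else on it.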